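Dimethylamino for hydroxy on the dienamide series

The compounds below may be only part of what the source reports. "The series", "measured", "known", "first", "only" and "open" are said of these compounds alone.

Three dienamides sharing one core have been measured in an assay for inhibition of Polyunsaturated fatty acid 5-lipoxygenase (Homo sapiens), read by spectrophotometry, tested at 20 uM; a higher number here means more inhibition at the concentration tested (going by the name of the read-out), a lower number less inhibition. Compound 1 `COc1ccc(/C=C/C=C/C(=O)N2CCCCC2)cc1OC` gives 51.9%, compound 2 `O=C(/C=C/C=C/c1ccc(O)cc1)N1CCCCC1` gives 44.4%, and compound 3 `COc1cc(/C=C/C=C/C(=O)N2CCCCC2)ccc1O` gives 55.5%. Compound 2 holds the lowest of the three numbers: its nearest neighbour is compound 1, within the scatter, and its furthest is compound 3, beyond it. The two single-point steps measured so far are a number 3.6 percentage points higher from compound 1 to compound 3 (within the scatter) and a number 11.1 percentage points higher from compound 2 to compound 3 (beyond the scatter).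

Compound 4 `CN(C)c1ccc(/C=C/C=C/C(=O)N2CCCCC2)cc1` differs from compound 2 in one place: dimethylamino in place of hydroxy on an aromatic carbon. Within the data shown here, no measured step exchanges hydroxy for dimethylamino. The step of a number 3.6 percentage points higher from compound 1 to compound 3 (within the scatter) shows that swapping hydrogen for methyl on an oxygen on an aromatic ring left this assay unmoved, and the step of a number 11.1 percentage points higher from compound 2 to compound 3 (beyond the scatter) shows a modest gain when methoxy enters; neither involves nitrogen. The expectation for compound 4 is therefore a step of a number 3.6 percentage points higher from compound 2 to compound 4 (within the scatter), not beyond the scatter. Compound 4 is estimated at 48% in this assay, with a range from 33% to 63%.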

Compound 4, a percentage reported as inhibition, at one concentration (the size of the read-out at that concentration, not a potency): 13.4%
Compound 4: the middle estimate sits 34.6 percentage points above what was measured, and the stated range ends above it.
By their numbers in this assay, from the lowest: compound 4; then compounds 2, 1 and 3 (each within the scatter of the next, the first and the last beyond it).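

In this assay, the aromatic carbon para to a large group proves sensitive to what it carries: dimethylamino in place of hydroxy gives a number 31 percentage points lower from compound 2 to compound 4 (beyond the scatter). Among these compounds, every earlier compound keeps an oxygen on this carbon, so this is the first step to place nitrogen there and the first large step. The donor count alone does not track the change, since going from 1 hydrogen-bond donor to 0 here coincides with the large drop, while a number 3.6 percentage points higher from compound 1 to compound 3 (within the scatter) links the same kind of difference on the oxygen to a shift within the scatter.

No measurement shown accounts for the drop. Going by these compounds, whether it follows the nitrogen itself or its two methyl groups remains open, and a plain amino group or a methylamino group on the same carbon would separate the two.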